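The source may report more compounds than this note shows. Statements on the series, on what has been measured and on what is new or still open speak of the compounds shown alone.

Measured compounds:
compound 1, `O=C1OC(c2ccc(F)cc2)C(c2ccc(O)cc2)=C1O`: 16.4%
compound 2, `O=C1OC(c2ccc(OCc3ccccc3)cc2)C(c2ccc(O)cc2)=C1O`: "not determined" (no result reported)

Among the measured compounds shown here, compound 1, `O=C1OC(c2ccc(F)cc2)C(c2ccc(O)cc2)=C1O`, is the only compound with a number. In an assay on blood for inhibition of Polyunsaturated fatty acid 5-lipoxygenase (Homo sapiens), tested at 100 uM (a higher number here means a stronger effect of the compound at the concentration tested, a lower number a weaker effect), compound 1 gives 16.4%. Compound 2, `O=C1OC(c2ccc(OCc3ccccc3)cc2)C(c2ccc(O)cc2)=C1O`, shares the core of compound 1, but in this assay compound 2 gives "not determined" (no result reported), so no single number describes where it stands; nothing measured separates it from compound 1.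

Compound 3, `O=C1OC(c2ccc(O)cc2)C(c2ccc(O)cc2)=C1O`, differs from compound 2 in one place: hydrogen in place of benzyl on an oxygen on an aromatic ring. Without a measured step between compound 2 and compound 3, and without a number for compound 2, the size of the step in this assay is open. A modest step in either direction, or none beyond the scatter, is equally plausible.

For the measured compounds named here, compound 3 is therefore expected near the single known value, at 20%, with an estimated range from 5% to 45%.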

Compound 3, a percentage reported as activity, at one concentration (the size of the read-out at that concentration, not a potency): 27.8%
The estimate for compound 3 lay 7.8 percentage points below the measured number; the measured number falls inside the stated range.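

Putting hydroxy in place of fluoro on an aromatic carbon gives a number 11.4 percentage points higher from compound 1 to compound 3 (beyond the scatter) in this assay and so shows that the read-out responds to what sits at this position on the shared core. Among the compounds shown here, this is the first measured step at this position, and it is a modest one. No evidence shown accounts for it.

The step between compound 2 and compound 3 cannot be read, and benzyloxy at this position therefore remains without a measured effect. As far as these compounds go, whether an amine, a methoxy group or a carboxylic acid on this aromatic carbon would raise or lower the read-out, or leave it within the scatter, remains open, as does whether the step seen here would hold on a different core.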